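The compounds below may be only part of what the source reports. "The series", "measured", "known", "first", "only" and "open" are said of these compounds alone.

Measured in an ADME assay on Raji cells (Homo sapiens) for cytotoxicity, read by luminescence, with a stated time of 72 h; on this read-out higher numbers stand for an effect only at larger amounts of compound and lower numbers for an effect already at smaller amounts:
Compound 1 `CCOC(=O)c1c(-c2ccccc2)[nH]c2cc(OC)ccc2c1=O`: > 21500 nM
Compound 2 `CCOC(=O)c1c(-c2cccc(OC)c2)[nH]c2cc(OC)ccc2c1=O`: > 21500 nM

Both entries are limits, not numbers. Compound 2 therefore has no exact place on the scale, and the position of the series is summed up as the limit of > 21500 nM in this assay, at which 2 of the 2 values shown sit.

Compound 3 `CCOC(=O)c1c(-c2cccc(OCC)c2)[nH]c2cc(OC)ccc2c1=O` is not yet measured. It carries 3-ethoxyphenyl where compound 2 carries 3-methoxyphenyl, so the change is methyl in place of hydrogen on a saturated chain carbon bound to an oxygen on an aromatic ring.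

Within the data shown here, the only measured step that bears on this is a step that the two limits leave unreadable from compound 1 to compound 2, which also concerns a substituent on that aromatic ring, with methoxy in place of hydrogen. It supplies no size to carry over. Among the measured compounds shown here, with that step unreadable and no measured compound below the limit, no step beyond the scatter is expected in this assay, in either direction, and a further report of only a limit is the likeliest outcome.

The expected change is a step that the limit leaves unreadable from compound 2 to compound 3. The estimate for compound 3 is 25000 nM, with an expected range of 12000 nM to 50000 nM.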

Compound 3, half-maximal effective concentration: > 21500 nM
Compound 3 was reported as a limit; the forecaster's own chance of this, stated with the estimate: 85%; the middle value is on the limit's open side.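

Compound 3, like compound 1 and compound 2, is reported in this assay only as a limit, so no step among these compounds can be read. The series stays at one position: the limit of > 21500 nM in this assay, at which 3 of the 3 values shown sit.

The compounds shown leave open where any of them lies on the scale, and whether methoxy or ethoxy in place of hydrogen changes the read-out at all.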